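Swapping the Aryl Group on the Sulfur of Compound 1

A few compounds are considered here, and "the series" means these few. Any claim that something is new, unique, unknown or untested is made for them only; others in the source may bear on it.

Of the compounds shown here, three have been measured in a functional assay on SMMC-7721 cells (Homo sapiens) for inhibition, read by CCK-8 assay, with a stated time of 72 h, tested at 8 uM; a lower number here means less inhibition of growth, a higher number more inhibition of growth at the concentration tested. Compound 1 `Cc1cc(C)cc(SCc2ccc(/C=C/C(=O)Nc3ccccc3N)cc2)c1` gives 7.13% and is the lowest of the three numbers. Compound 2 `COc1ccc(SCc2ccc(C(=O)Nc3ccccc3N)cc2)cc1` gives 80.1%, and compound 3 `COC(=O)c1ccccc1SCc1ccc(C(=O)Nc2ccccc2N)cc1` gives 62.5%. Compound 1 thus sits well apart from both: its nearest neighbour on the numbers is compound 3, and the furthest is compound 2, each of them beyond the scatter and higher. Within the data shown here, compounds 2 and 3 differ from compound 1 in more than one place, so no single step between measured compounds can be read from them.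

The unmeasured compound 4 `CC(C)(C)c1ccc(SCc2ccc(/C=C/C(=O)Nc3ccccc3N)cc2)cc1` differs from compound 1 in one place: 4-(tert-butyl)phenyl in place of 3,5-dimethylphenyl on a sulfur. Among the measured compounds shown here, no measured pair shows what such a change does in this assay. For the measured compounds named here, with no step to lean on, the step from compound 1 to compound 4 is expected to be small, most likely within the scatter, with a slight lean upward allowed for, giving an expected a number 6.9 percentage points higher from compound 1 to compound 4 (within the scatter). Compound 4 is therefore estimated at 14%, with a range from 0% to 40%.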

Compound 4, percent growth inhibition at one concentration: 23.6%
Estimate against measurement, compound 4: 9.6 percentage points below; the range from low to high includes it.
By their numbers in this assay, from the lowest: compound 1; then compound 4; then compound 3; then compound 2.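

Among these compounds, the exchange on this sulfur is the first single change that can be read in this assay: 4-(tert-butyl)phenyl in place of 3,5-dimethylphenyl gives a number 16.5 percentage points higher from compound 1 to compound 4 (beyond the scatter). The step is modest, but it shows that the number responds to the aryl group at this place, even though the leaving and entering groups are both carbon-only aromatic groups without hydrogen-bond donors or acceptors, with 8 and 10 heavy atoms. No measurement on hand accounts for the step.

This single pair does not separate the loss of the two methyl groups from the arrival of the tert-butyl group, so neither can be credited with the step on its own. It also leaves open what a plain phenyl, a 4-fluorophenyl or a pyridine ring on the same sulfur would give in this assay, and whether the same exchange would shift the number in the same direction on the core of compound 2.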